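From Chloro to Methoxy at the Assay Limit

A few compounds are considered here, and "the series" means these few. Any claim that something is new, unique, unknown or untested is made for them only; others in the source may bear on it.

Compound 1 `CCNC(=O)CCc1cccc2c1B(O)OC2` gives > 100000 nM as a limit
Compound 2 `O=C(CCc1cccc2c1B(O)OC2)Nc1nccs1` gives > 100000 nM as a limit
Compound 3 `O=C(CCc1cccc2c1B(O)OC2)Nc1ccc(Cl)cc1` gives > 100000 nM as a limit

All three entries come from an ADME assay on WI-38 cells (Homo sapiens) for cytotoxicity, read by MTT assay, with a stated time of 72 h (a higher number here means a weaker inhibitor, a lower number a stronger inhibitor), and each is a limit rather than a number. Compound 3 stands at > 100000 nM as a limit of the assay. The other two compounds share that position, as the limit of > 100000 nM in this assay, at which 3 of the 3 values shown sit, records.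

Compound 4 `COc1ccc(NC(=O)CCc2cccc3c2B(O)OC3)cc1` differs from compound 3 by a single exchange, methoxy in place of chloro on an aromatic carbon, para to a large group.

The measured steps that bear on this change are a step that the two limits leave unreadable from compound 1 to compound 3 and a step that the two limits leave unreadable from compound 2 to compound 3, along with a step that the two limits leave unreadable from compound 1 to compound 2. None of them has a readable size. They show only that the ethyl, 1,3-thiazol-2-yl and 4-chlorophenyl compounds all end at the same limit, and none of them tests methoxy. Because of the limit of > 100000 nM in this assay, at which 3 of the 3 values shown sit, no step beyond the usual scatter is expected in this assay, and no direction can be favoured. The expected size is a number no higher from compound 3 to compound 4 (the limit leaves the size open), and compound 4 will most likely be reported as a limit too. The estimate for compound 4 is 100000 nM (expected range 40000 nM to 200000 nM).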

Compound 4, half-maximal inhibitory concentration: > 100000 nM
Compound 4: a limit, no number (the forecaster's own chance of this, stated with the estimate: 85%); the middle value sits exactly at the limit.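

Compound 3 and compound 4 both end at a limit rather than a number, so the exchange of chloro for methoxy has no readable size, and the same holds for every other step here: the limit of > 100000 nM in this assay, at which 4 of the 4 values shown sit.

The compounds shown leave open at what concentration any of them would begin to harm the cells, and whether the groups on the amide nitrogen differ in that respect.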